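The compounds below may be only part of what the source reports. "The series", "measured", "known", "first", "only" and "open" are said of these compounds alone.

For the measured compounds named here, compound 2 `CC[C@H](C)[C@@H]1C(=O)N[C@H](C2Cc3ccccc3C2)C(=O)N1[C@@H](C(=O)N(C)C)c1cnc(C)cc1C` gives 0.0398 nM in an assay on isolated protein for displacement of a labelled ligand from Oxytocin receptor (Homo sapiens) (a lower number here means a stronger inhibitor, a higher number a weaker inhibitor), the lowest of the two numbers so far. Going by the values given here, compound 1 `CC[C@H](C)[C@@H]1C(=O)N[C@H](C2Cc3ccccc3C2)C(=O)N1[C@@H](C(=O)N(C)C)c1cc(C)cnc1C` gives 0.794 nM in this assay, and the single measured step, a 20-fold lower number from compound 1 to compound 2 (1.30 log units; beyond the scatter), exchanges 2,5-dimethylpyridin-3-yl for 4,6-dimethylpyridin-3-yl and leaves the amide untouched. Compound 3 `CC[C@H](C)[C@@H]1C(=O)N[C@H](C2Cc3ccccc3C2)C(=O)N1[C@@H](C(=O)N1CCOCC1)c1cnc(C)cc1C` carries morpholin-4-yl in place of dimethylamino on a carbonyl carbon. Among the compounds with values here, no measured step bears on the dimethylcarbamoyl to (morpholin-4-yl)carbonyl change, so compound 3 is expected to show a step of a 1.3-fold higher number from compound 2 to compound 3 (0.10 log units; within the scatter), within the scatter. Compound 3 is therefore estimated at 0.05 nM, with a range from 0.015 nM to 0.2 nM.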

Compound 3, inhibition constant: 0.0501 nM
Compound 3: middle estimate off by 1.0-fold (0.00 log units), on the low side, and the stated range covers the measured number.
By their numbers in this assay, from the lowest: compounds 2 and 3 (each within the scatter of the next); then compound 1.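

At the carbonyl carbon, where compounds 1 and 2 both carry dimethylamino, morpholin-4-yl brings a six-membered ring and a hydrogen-bond acceptor, yet this assay shows only a small difference (a 1.3-fold higher number from compound 2 to compound 3 (0.10 log units; within the scatter)). This exchange at the amide therefore stays within the scatter, unlike the earlier exchange on the pyridine (a 20-fold lower number from compound 1 to compound 2 (1.30 log units; beyond the scatter)). No evidence at hand bears on the reason for this result.

As far as these compounds go, whether piperazin-1-yl or a plain amino group on the same carbonyl carbon would also leave the number in place remains open. So does whether morpholin-4-yl would behave alike alongside the 2,5-dimethylpyridin-3-yl of compound 1.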